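Adding methyl to the amide nitrogen of compound 3

The source may report more compounds than this note shows. Statements on the series, on what has been measured and on what is new or still open speak of the compounds shown alone.

Measured in a functional assay on the whole organism with Rattus norvegicus as the target; a lower number here means that less compound is needed, a higher number that more compound is needed for the effect:
- compound 1 `COc1cc(N(C)C)c(Cl)cc1C(=O)NC1CCN(Cc2ccccc2)C1`: 0.12 mg/kg
- compound 2 `COc1cc(NC=O)c(Cl)cc1C(=O)NC1CCN(Cc2ccccc2)C1`: 0.6 mg/kg
- compound 3 `COc1cc(NC(C)=O)c(Cl)cc1C(=O)NC1CCN(Cc2ccccc2)C1`: 1.8 mg/kg

Going by the values given here, compound 3, at 1.8 mg/kg, has the highest number of the series so far, and more compound is needed for the effect than with either neighbour: a 3.0-fold higher number from compound 2 to compound 3 (0.48 log units; beyond the scatter), and a 15-fold higher number from compound 1 to compound 3 (1.18 log units; beyond the scatter). Compound 4 `COc1cc(N(C)C(C)=O)c(Cl)cc1C(=O)NC1CCN(Cc2ccccc2)C1` carries methyl in place of hydrogen on an amide-type nitrogen. Among the compounds with values here, no measured step makes this exact change, and its effect in this assay remains open. The nearest evidence is a methyl added elsewhere on the same acylamino group, a 3.0-fold higher number from compound 2 to compound 3 (0.48 log units; beyond the scatter), a modest rise. The steps of a 5.0-fold higher number from compound 1 to compound 2 (0.70 log units; beyond the scatter) and a 15-fold higher number from compound 1 to compound 3 (1.18 log units; beyond the scatter) replace dimethylamino with acylated groups, so they bear on this change only indirectly. A modest rise is therefore expected, although a result within the scatter would not be surprising. The expected step is a 1.7-fold higher number from compound 3 to compound 4 (0.22 log units; within the scatter). For compound 4 the estimated value is 3 mg/kg, within an expected range of 1 mg/kg to 10 mg/kg.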

Compound 4, dose for half-maximal effect: > 30 mg/kg
Compound 4: a limit, no number; the forecaster's own chance of this, stated with the estimate: 10%; at least 10-fold (1.00 log units) between middle value and limit.
By their numbers in this assay, from the lowest: compound 1; then compound 2; then compound 3. At a limit, above all of these: compound 4.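

In this assay compound 4 stands as a limit of the assay and not as a number: the limit of > 30 mg/kg in this assay, at which 1 of the 4 values shown sits.
On the amide-type nitrogen, methyl in place of hydrogen is a large step (an at least 16-fold higher number from compound 3 to compound 4 (1.22 log units; beyond the scatter)), whereas the methyl added on the carbonyl carbon gave only a modest one. Methyl on this nitrogen does not account for this alone, as compound 1 also carries methyl there; the large steps appear where acetyl and methyl share the nitrogen (an at least 250-fold higher number from compound 1 to compound 4 (2.39 log units; beyond the scatter); an at least 50-fold higher number from compound 2 to compound 4 (1.69 log units; beyond the scatter)).

The limit leaves the true size of all three steps open. Going by these compounds, it also remains open whether formyl(methyl)amino or a plain methylamino group on the aromatic carbon would read closer to compound 1 or to compound 4.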